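Swapping a para-hydroxyphenyl for a chlorophenyl

This account rests on a few compounds, and the source may have more. Where it says the series, first, only, none or still open, it means among the compounds named here.

Measured compounds:
compound 1, `Clc1ccc(Nc2ccc(N3CC4CC(C3)N4)cn2)cc1`, 2.49 nM
compound 2, `c1ccc(Nc2ccc(N3CC4CC(C3)N4)cn2)cc1`, 2.66 nM
compound 3, `Oc1ccc(Nc2ccc(N3CC4CC(C3)N4)cn2)cc1`, 7.1 nM

All three compounds share one core and differ only in the group on the phenyl ring. In an assay on cell membranes for displacement of a labelled ligand from Neuronal acetylcholine receptor; alpha4/beta2 (Rattus norvegicus) (a higher number here means a weaker inhibitor, a lower number a stronger inhibitor), compound 3 gives the highest number of the three, and both of its steps to the others lie beyond the scatter: a 2.9-fold higher number from compound 1 to compound 3 (0.46 log units; beyond the scatter) and a 2.7-fold higher number from compound 2 to compound 3 (0.43 log units; beyond the scatter). Compounds 1 and 2, in turn, sit within the scatter of each other, a 1.1-fold higher number from compound 1 to compound 2 (0.03 log units; within the scatter), so no order between them is claimed.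

Compound 4, `Clc1cccc(Nc2ccc(N3CC4CC(C3)N4)cn2)c1`, is not yet measured. Its change from compound 3 is 3-chlorophenyl in place of 4-hydroxyphenyl on a nitrogen on an aromatic ring. Among the compounds with values here, two measured steps bear on it. Removing the hydroxy group, read backwards from compound 3 to compound 2, lowers the number by a modest amount, and replacing it with chloro, read backwards from compound 3 to compound 1, does about the same. The chloro in compound 4 sits at a different place on the ring than in compound 1, for which no measurement exists, so the reading is less certain. The expected step in this assay is a 2.6-fold lower number from compound 3 to compound 4 (0.42 log units; beyond the scatter), a modest fall in the number. Compound 4 is therefore estimated at 2.7 nM, with a range of 1.2 nM to 6.5 nM.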

Compound 4, inhibition constant: 2.2 nM
Compound 4: the middle estimate sits 1.2-fold (0.09 log units) above what was measured; the measured number falls inside the stated range.
By their numbers in this assay, from the lowest: compounds 4, 1 and 2 (each within the scatter of the next); then compound 3.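

In this assay, within the data shown here, the single change of 3-chlorophenyl in place of 4-hydroxyphenyl gives a 3.2-fold lower number from compound 3 to compound 4 (0.51 log units; beyond the scatter), so a ring carrying chloro in the other place also stands clear of the hydroxy compound, which the earlier compounds could not show. The new group also sits level with the two earlier groups, with the plain phenyl (a 1.2-fold lower number from compound 2 to compound 4 (0.08 log units; within the scatter)) and with the 4-chlorophenyl (a 1.1-fold lower number from compound 1 to compound 4 (0.05 log units; within the scatter)), so neither adding this chloro nor shifting it along the ring produces a step beyond the scatter. Among these four compounds, compound 3 alone stands apart, while the other three cannot be ordered, and no measurement shown here gives any reason for that difference.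

The step to compound 4 changes the group and its place on the ring together. These compounds therefore do not settle whether the higher number of compound 3 belongs to the hydroxy group itself or to its place, and a 3-hydroxyphenyl would separate the two. They also leave open how far the flat picture extends, since a methoxy group, an amino group or a carboxylic acid on the same ring could fall with the chloro compounds, with compound 3 or elsewhere.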